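The compounds below may be only part of what the source reports. "The series", "measured", "known", "first", "only" and "open" are said of these compounds alone.

Two members of the series have been taken through a functional assay on HCT-116 cells (Homo sapiens) for cytotoxicity, read by MTT assay, with a stated time of 48 h (on this read-out higher numbers stand for weaker inhibition and lower numbers for stronger inhibition), so far. Compound 1 `COc1ccc(N/C=C\C(=O)c2nc(-c3ccc(OC)cc3)n3ccccc23)cc1` gives no number in this assay; its result, > 30000 nM, is a limit of the assay. Compound 2 `O=C(/C=C\Nc1ccc(F)cc1)c1nc(-c2ccc(C(F)(F)F)cc2)n2ccccc12` likewise reaches only a limit in this assay, > 30000 nM. Both results therefore sit at the limit of > 30000 nM in this assay, at which 2 of the 2 values shown sit, and nothing in the measured pair tells how far apart the two compounds really lie.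

Compound 3 `COc1ccc(-c2nc(C(=O)/C=C\Nc3ccc(F)cc3)c3ccccn23)cc1` keeps the enamine and the shared core of compound 2 and carries a single change, methoxy in place of trifluoromethyl on an aromatic carbon. Among the measured compounds shown here, the methoxy-bearing aryl is the one already present in compound 1, which also gave only a limit. No change beyond the scatter is expected from compound 2 to compound 3 in this assay, and the step that the limit leaves unreadable from compound 2 to compound 3 is an estimate only. Compound 3 is expected to come out near 40000 nM in this assay, most likely again as a limit, with the plausible range 12000 nM to 120000 nM.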

Compound 3, half-maximal inhibitory concentration: > 30000 nM
Compound 3 gave a limit, no number; the forecaster's own chance of this, stated with the estimate: 80%; the middle value is on the limit's open side.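

Compound 3, like compound 1 and compound 2, gives only a limit in this assay, so no step among the three can be read: the limit of > 30000 nM in this assay, at which 3 of the 3 values shown sit.

The compounds shown leave open where their true values lie and whether methoxy and trifluoromethyl differ at all in this read-out.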